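A few compounds are considered here, and "the series" means these few. Any claim that something is new, unique, unknown or untested is made for them only; others in the source may bear on it.

Of the compounds shown here, three of one series have been measured in a functional assay on CHO cells for agonist activity at adenosine receptor A2b (Homo sapiens), read by AlphaScreen and cAMP accumulation; a higher number here means that more compound is needed for the effect, a lower number that less compound is needed. Compound 1 `N#Cc1c(N)nc(SCC(N)=O)c(C#N)c1-c1ccc(OCC2CC2)cc1` gives 31 nM. Compound 2 `CCOc1ccc(-c2c(C#N)c(N)nc(SCc3ccn[nH]3)c2C#N)cc1` gives 332 nM. Compound 3 `N#Cc1c(N)nc(SCc2ccn[nH]2)c(C#N)c1-c1ccc(OCC2CC2)cc1` gives 84 nM, the second highest of the three numbers; its nearest neighbour is compound 1, and its furthest is compound 2. The two steps that reach compound 3 are a 2.7-fold higher number from compound 1 to compound 3 (0.43 log units; beyond the scatter) and a 4.0-fold lower number from compound 2 to compound 3 (0.60 log units; beyond the scatter).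

Compound 4 `N#Cc1c(N)nc(SCC(=O)NCO)c(C#N)c1-c1ccc(OCC2CC2)cc1` differs from compound 3 in one place: (hydroxymethyl)carbamoyl in place of 1H-pyrazol-5-yl on a saturated chain carbon bound to a sulfur. Among the compounds with values here, of the two measured steps, only the one from compound 1 bears on this change, since it alters the same saturated chain carbon bound to a sulfur; the step from compound 2 concerns the cyclopropyl side, which compound 3 and compound 4 share. Compound 1 carries a carbamoyl at this place, and the group that enters in compound 4 is a carbamoyl that bears a hydroxymethyl. The step from compound 3 back toward a carbamoyl is therefore expected to undo most of what a 2.7-fold higher number from compound 1 to compound 3 (0.43 log units; beyond the scatter) showed, with the hydroxymethyl left as an unknown of modest weight. Compound 4 is therefore expected to give 40 nM in this assay, between 15 nM and 110 nM, which means an expected step of a 2.1-fold lower number from compound 3 to compound 4 (0.32 log units; beyond the scatter).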

Compound 4, half-maximal effective concentration: 182 nM
Beside the measured number, compound 4's estimate is 4.6-fold (0.66 log units) below it; the measured number lies above the stated range.
By their numbers in this assay, from the lowest: compound 1; then compound 3; then compounds 4 and 2 (each within the scatter of the next).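

Compound 4 shows that at the saturated chain carbon bound to a sulfur, the carbamoyl does not keep its low number once the amide-type nitrogen is changed: in this assay, hydroxymethyl in place of hydrogen gives a 5.9-fold higher number from compound 1 to compound 4 (0.77 log units; beyond the scatter) and so counts as a substantial change in its own right, although the step is still graded modest. The same group also stands behind the 1H-pyrazol-5-yl, with a 2.2-fold higher number from compound 3 to compound 4 (0.34 log units; beyond the scatter), so that with the cyclopropyl side held fixed the three groups run from carbamoyl, through 1H-pyrazol-5-yl, to (hydroxymethyl)carbamoyl. Nothing measured here accounts for either step.

The compounds shown leave open whether a methyl or a longer chain such as 2-hydroxyethyl on the amide-type nitrogen would raise the number as the hydroxymethyl does, or whether a carboxylic acid at this place would follow the carbamoyl or the (hydroxymethyl)carbamoyl. They also leave open whether the same order of groups holds with the methyl of compound 2 in place of the cyclopropyl.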